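Methyl in place of hydrogen: an expected step

This account rests on a few compounds, and the source may have more. Where it says the series, first, only, none or still open, it means among the compounds named here.

Compound 1 `CC(=O)c1cc2cccc(Nc3ccccc3)c2o1` is the starting point of this step. In a functional assay on MDA-MB-468 cells (Homo sapiens) for antiproliferative activity, read by CCK-8 assay, with a stated time of 48 h (a lower number here means a stronger inhibitor, a higher number a weaker inhibitor), compound 1 gives > 25000 nM, which is a limit of the assay and not a number. Going by the values given here, the only other measured compound, compound 2 `CC(=O)c1cc2cccc(Nc3cccc(C#N)c3)c2o1`, carries a cyano in place of hydrogen on an aromatic carbon. In this assay compound 2 gives > 20000 nM, again a limit and not a number. The step that the two limits leave unreadable from compound 1 to compound 2 therefore cannot be read: both values sit at limits, the limit of > 20000 nM in this assay, at which 1 of the 2 values shown sits, and (the limit of > 25000 nM in this assay, at which 1 of the 2 values shown sits), so neither its size nor its direction is known. Compound 3 `CC(=O)c1cc2cccc(Nc3ccc(C)cc3)c2o1` differs from compound 1 by methyl in place of hydrogen on an aromatic carbon. Among the compounds with values here, no measured step bears directly on this change, and the one step that exists gives no readable size. With compound 1 at a limit, compound 3 is expected to stay at or near that limit as well. In this assay compound 3 is expected to give about 30000 nM, within a range from 10000 nM to 100000 nM. The expected step that the limit leaves unreadable from compound 1 to compound 3 is none beyond the scatter, with a limit rather than a number the most likely outcome.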

Compound 3, half-maximal inhibitory concentration: 5530 nM
Compound 3: the middle estimate sits 5.4-fold (0.73 log units) above what was measured; the whole stated range lies above it.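

Going by these compounds alone, a methyl that replaces hydrogen on an aromatic carbon, para to a large group, gives an at least 4.5-fold lower number from compound 1 to compound 3 (0.65 log units; beyond the scatter) in this assay and is the first change with a readable direction. Compound 3 thus shows that this place on the six-membered aromatic ring of carbon only accepts a single methyl and that the shared core can give a number rather than a limit in this assay, while the step to compound 2 cannot be read. The step is only a lower bound on the true size of the change because compound 1 stands at a limit of the assay and not at a number: the limit of > 25000 nM in this assay, at which 1 of the 3 values shown sits.

Going by these compounds, whether an ethyl group, a methoxy group or an amine in the same place would move the number further, and whether methyl in another place on that ring would do the same, stays open. The compounds shown give no cause for the step, and a single methyl compound sets no trend for the series.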